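Same Halogenated Phenyl Swap, Second Core

The compounds below may be only part of what the source reports. "The series", "measured", "known", "first", "only" and "open" are said of these compounds alone.

Three compounds have been measured in a functional assay on A549 cells (Homo sapiens) for cytotoxicity, read by MTT assay, with a stated time of 72 h; a lower number here means a stronger inhibitor, a higher number a weaker inhibitor:
compound 1 `O=C(Nc1ccc(Oc2ccnc3[nH]ccc23)c(F)c1)c1nn(-c2ccccc2)ccc1=O` gives 56800 nM;
compound 2 `O=C(Nc1ccc(Oc2ccnc3[nH]ccc23)c(F)c1)c1nn(-c2ccc(Br)cc2F)ccc1=O` gives 55700 nM;
compound 3 `Cn1ccc2c(Oc3ccc(NC(=O)c4nn(-c5ccccc5)ccc4=O)cc3)ccnc21` gives 51700 nM.

Compound 4 `Cn1ccc2c(Oc3ccc(NC(=O)c4nn(-c5ccc(Br)cc5F)ccc4=O)cc3)ccnc21` is not yet measured. Compound 3 and compound 4 differ by 4-bromo-2-fluorophenyl in place of phenyl on an aromatic nitrogen. The same change was already made once, from compound 1 to compound 2, where it gave a 1.0-fold lower number from compound 1 to compound 2 (0.01 log units; within the scatter). The surroundings of the change are described in identical words in both pairs, so this is the same change on a second core; the difference between the core of compound 1 and the core of compound 3 is not broken down here. The values of compound 1, compound 2 and compound 3 all lie within the scatter of one another. The step from compound 3 to compound 4 is expected to be a 1.0-fold lower number from compound 3 to compound 4 (0.01 log units; within the scatter) because the earlier step gave a 1.0-fold lower number from compound 1 to compound 2 (0.01 log units; within the scatter). Compound 4 is therefore estimated at 51000 nM in this assay, between 25000 nM and 100000 nM.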

Compound 4, half-maximal inhibitory concentration: 35700 nM
Estimate against measurement, compound 4: 1.4-fold (0.15 log units) above, within the range that was stated.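

In this assay, putting 4-bromo-2-fluorophenyl in place of phenyl on the second core gives a 1.4-fold lower number from compound 3 to compound 4 (0.16 log units; within the scatter). Set beside the same change on the first core, this step shows no difference that repeated measurement could not produce: the same change on two cores in this assay, a 1.0-fold lower number (0.01 log units; within the scatter) from compound 1 to compound 2 and a 1.4-fold lower number (0.16 log units; within the scatter) from compound 3 to compound 4, 1.4-fold (0.15 log units) apart, within the scatter of two such steps. The change therefore behaves alike on these two cores, but neither step rises above the scatter, so this shows only that it does little on both, not that a real effect carries from one core to the other.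

Bromine and fluorine enter together, so what each does alone stays open. Also open, from the compounds shown here alone, is whether an amine or a carboxylic acid in place of the 4-bromo-2-fluorophenyl would move the number beyond the scatter.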